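Notes on the aromatic nitrogen substituent, compound 3 to compound 4

The compounds below may be only part of what the source reports. "The series", "measured", "known", "first", "only" and "open" are said of these compounds alone.

Measured so far:
compound 1 `O=C(O)C1=Cc2ccccc2OC1(OCc1cc(-c2ccc(F)cc2)no1)C(F)(F)F` — 64200 nM
compound 2 `CCOC(=O)C1=Cc2ccccc2OC1(OCc1cc(-c2ccc(OC)cc2)no1)C(F)(F)F` — > 150000 nM (a limit)
compound 3 `CCOC(=O)C1=Cc2ccccc2OC1(OCc1cn(-c2ccccc2)nn1)C(F)(F)F` — > 150000 nM (a limit)

In a functional assay on MCF7 cells (Homo sapiens) for inhibition, read by MTT assay, with a stated time of 24 h (a higher number here means a weaker inhibitor, a lower number a stronger inhibitor), compound 1 gives 64200 nM. Compound 2 returns only > 150000 nM in this assay, which is a limit of the assay and not a number. Compound 3 likewise returns only > 150000 nM, again a limit rather than a number. Compound 3 therefore stands at the limit of > 150000 nM in this assay, at which 2 of the 3 values shown sit, and no numbered value places it within the series.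

Compound 4 `CCOC(=O)C1=Cc2ccccc2OC1(OCc1cn(CC(=O)Nc2cccc(Cl)c2)nn1)C(F)(F)F` differs from compound 3 in one place: ((3-chlorophenyl)carbamoyl)methyl in place of phenyl on an aromatic nitrogen. Among the measured compounds shown here, no step between two measured compounds touches that position, so no measured size is available to lean on. The working expectation is a step of no more than the usual scatter, in no clear direction, with compound 4 most likely also sitting at the limit of this assay.

For compound 4 in this assay the expected value is estimated at 150000 nM, within 50000 nM to 400000 nM, which means an estimated step of a number no higher from compound 3 to compound 4 (the limit leaves the size open).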

Compound 4, half-maximal inhibitory concentration: 11600 nM
The estimate for compound 4 lay 13-fold (1.11 log units) above the measured number, outside the stated range (below it).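

In this assay, ((3-chlorophenyl)carbamoyl)methyl in place of phenyl on the aromatic nitrogen gives an at least 12-fold lower number from compound 3 to compound 4 (1.11 log units; beyond the scatter), so this position responds strongly to substitution. The entering group keeps a six-membered aromatic ring of carbon only but adds a carbonyl and the amide hydrogen, and this single step cannot divide the gain among the chain, the amide and the chlorine. Compound 3 stands at a limit and not a number, so the true size of the step remains open: the limit of > 150000 nM in this assay, at which 2 of the 4 values shown sit.

The compounds shown leave open whether the chlorine contributes at all and whether the amide alone carries the step. An amine or a longer chain in place of the amide link, or a carboxylic acid in place of the ethyl ester alongside this group, would remain to be compared.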